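Cyclopentyl for furanylmethyl on the anilinic nitrogen

This account rests on a few compounds, and the source may have more. Where it says the series, first, only, none or still open, it means among the compounds named here.

Two compounds of this series have numbers in an assay on cells for inhibition of serine/threonine-protein kinase WNK1 (Homo sapiens), read by luminescence and Kinase-Glo, with a stated time of 2 h; on this read-out lower numbers stand for stronger inhibition and higher numbers for weaker inhibition. Compound 1 `O=[N+]([O-])c1cc(S(=O)(=O)C(Cl)(Cl)Br)ccc1NC1CCCCC1` gives 4000 nM in this assay. Compound 2 `O=[N+]([O-])c1cc(S(=O)(=O)C(Cl)(Cl)Br)ccc1NCc1ccco1` gives 15000 nM in this assay; it stands highest of the two numbers, with compound 1 as its nearest neighbour at a lower number, the gap lying beyond the scatter. Among the compounds with values here, the single measured step, a 3.8-fold higher number from compound 1 to compound 2 (0.57 log units; beyond the scatter), moves from a saturated carbocycle on the nitrogen to the heteroaromatic methyl group.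

Compound 3 `O=[N+]([O-])c1cc(S(=O)(=O)C(Cl)(Cl)Br)ccc1NC1CCCC1` is not yet measured. Its difference from compound 2 is cyclopentyl in place of (furan-2-yl)methyl on a nitrogen on an aromatic ring. The step from compound 1 to compound 2 bears on it directly, as it reverses the same kind of exchange: a saturated carbocycle of carbon only leaves in favour of the furanylmethyl group there, whereas here a saturated carbocycle of carbon only enters in its place. The only difference is ring size, one member fewer than in compound 1. A return toward the number of compound 1 is therefore expected, roughly of the size of that measured step, in the downward direction. The estimated step is a 3.0-fold lower number from compound 2 to compound 3 (0.48 log units; beyond the scatter). For compound 3 the expected value in this assay is 5000 nM, with a range from 2000 nM to 12000 nM.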

Compound 3, half-maximal inhibitory concentration: 93000 nM
Compound 3: the middle estimate sits 19-fold (1.27 log units) below what was measured, outside the stated range (above it).
By their numbers in this assay, from the lowest: compound 1; then compound 2; then compound 3.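

The two saturated carbocycles on this nitrogen do not behave alike in this assay: the exchange of cyclohexyl for cyclopentyl gives a 23-fold higher number from compound 1 to compound 3 (1.37 log units; beyond the scatter) and is the largest change in the set, so a ring of carbon only does not in itself secure the lower number. The (furan-2-yl)methyl group does not mark the weak end of the series either, since the replacement of that group by cyclopentyl gives a 6.2-fold higher number from compound 2 to compound 3 (0.79 log units; beyond the scatter) and leaves compound 2 in the middle of the order, with one carbocycle on either side of it. Thus the ranking at this position does not follow the division into carbocyclic and heteroaromatic groups, and the compounds shown carry no measurement that explains the gap between cyclohexyl and cyclopentyl.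

Cycloheptyl and cyclobutyl on the same nitrogen would show whether the number changes steadily with ring size or whether cyclohexyl stands alone. As far as these compounds go, it also remains open whether benzyl or (tetrahydrofuran-2-yl)methyl would fall nearer to compound 1, to compound 2 or to compound 3, which would separate the contributions of the methylene link, the ring oxygen and the aromatic ring.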